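This account rests on a few compounds, and the source may have more. Where it says the series, first, only, none or still open, it means among the compounds named here.

Compound 1 `CC(=O)Cn1nnc(CNC(=O)c2ccc(-c3ccccc3)cc2)n1` and compound 2 `CC(C)Cn1nnc(CNC(=O)c2ccc(-c3ccccc3)cc2)n1` share one core and differ only on the saturated chain carbon bound to an aromatic nitrogen. In an assay for inhibition of Fatty-acid amide hydrolase 1 (Rattus norvegicus) (on this read-out lower numbers stand for stronger inhibition and higher numbers for weaker inhibition), compound 1 gives only a limit, > 50000 nM. In this assay compound 2 also gives only a limit, > 50000 nM. The step that the two limits leave unreadable from compound 1 to compound 2 is therefore unreadable, both values sitting at the limit of > 50000 nM in this assay, at which 2 of the 2 values shown sit. Compound 3 `COC(=O)Cn1nnc(CNC(=O)c2ccc(-c3ccccc3)cc2)n1` differs from compound 2 by methoxycarbonyl in place of isopropyl on a saturated chain carbon bound to an aromatic nitrogen. Among the compounds with values here, no measured step bears readably on this change. Compound 3 is therefore expected to stay near the limit, with an estimated step that the limit leaves unreadable from compound 2 to compound 3 in this assay. The estimate for compound 3 is 60000 nM, within 15000 nM to 200000 nM.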

Compound 3, half-maximal inhibitory concentration: > 50000 nM
Compound 3 ended at the assay's limit (the forecaster's own chance of this, stated with the estimate: 75%); the middle value does not contradict the limit.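

No new step can be read from compound 1, compound 2 and compound 3, which all sit at one limit: the limit of > 50000 nM in this assay, at which 3 of the 3 values shown sit.
The compounds shown leave open whether any group on the saturated chain carbon bound to an aromatic nitrogen gives a readable value.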